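The compounds below may be only part of what the source reports. "The series", "measured", "known", "first", "only" and "open" are said of these compounds alone.

compound 1 `COc1cc(C(=O)c2cn(-c3ccccc3)cc2-c2cccc(Br)c2)cc(OC)c1OC` gives 950 nM
compound 2 `COc1cccc(-c2cn(-c3ccccc3)cc2C(=O)c2cc(OC)c(OC)c(OC)c2)c1` gives 180 nM
compound 3 `COc1ccc(-c2cn(-c3ccccc3)cc2C(=O)c2cc(OC)c(OC)c(OC)c2)cc1` gives 70 nM

All three values come from one test (a functional assay on MCF7 cells (Homo sapiens) for cytotoxicity, read by MTT assay, with a stated time of 96 h; on this read-out lower numbers stand for stronger inhibition and higher numbers for weaker inhibition). Compound 3 has the lowest number of the three, and the steps that reach it (a 14-fold lower number from compound 1 to compound 3 (1.13 log units; beyond the scatter)) and (a 2.6-fold lower number from compound 2 to compound 3 (0.41 log units; beyond the scatter)) both lie beyond the scatter. The remaining step (a 5.3-fold lower number from compound 1 to compound 2 (0.72 log units; beyond the scatter)) is also beyond the scatter, so each change to this one group on the shared core has moved the number.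

The unmeasured compound 4 `COc1cc(C(=O)c2cn(-c3ccccc3)cc2-c2cc(F)ccc2F)cc(OC)c1OC` changes the same place, with 2,5-difluorophenyl in place of 4-methoxyphenyl on an aromatic carbon. Within the data shown here, no measured compound carries fluorine, so the steps above offer only indirect guidance. Among the measured compounds shown here, compound 1 is the only measured compound without a methoxy on this ring, and it has the highest number (950 nM). Compound 4 also lacks that methoxy, so a higher number than that of compound 3 is expected, with a modest to large step. The estimated change is (a 5.7-fold higher number from compound 3 to compound 4 (0.76 log units; beyond the scatter)). Compound 4 is expected to give about 400 nM in this test. The estimated range for compound 4 runs from 120 nM to 1500 nM and remains wide.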

Compound 4, half-maximal inhibitory concentration: 230 nM
Estimate against measurement, compound 4: 1.7-fold (0.24 log units) above, within the range that was stated.
By their numbers in this assay, from the lowest: compound 3; then compounds 2 and 4 (each within the scatter of the next); then compound 1.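

In this assay, the lack of a methoxy on this ring does not by itself give a number as high as that of compound 1: the change of 3-bromophenyl to 2,5-difluorophenyl gives a 4.1-fold lower number from compound 1 to compound 4 (0.62 log units; beyond the scatter), so compound 4 goes against the link between methoxy and a low number that the first three compounds suggested. The step to the 3-methoxyphenyl compound is a 1.3-fold higher number from compound 2 to compound 4 (0.11 log units; within the scatter), so these two groups cannot be told apart at this position in this test, even though only one of them carries a methoxy. The 4-methoxyphenyl group still keeps the lowest number, with a 3.3-fold higher number from compound 3 to compound 4 (0.52 log units; beyond the scatter), but nothing shown here gives a reason for any of these differences.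

Going by these compounds, compound 4 carries both fluorines in a single group, so what each one contributes stays open, as does whether a single fluorine on this ring would give a similar number. How a phenyl ring carrying an amine or a carboxylic acid would behave at this position also remains an open question.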